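This account rests on a few compounds, and the source may have more. Where it says the series, first, only, none or still open, it means among the compounds named here.

Measured so far:

Compound 1, `COC(=O)/C=C/c1cccc(N(Cc2ccc(/C=C/c3c(Cl)cccc3Cl)cc2)C(=O)C(C)C)c1`, gives 195 nM in an assay on isolated protein with Bile acid receptor (Homo sapiens) as the target; a higher number here means that more compound is needed for the effect, a lower number that less compound is needed.
Compound 2, `COC(=O)/C=C/c1cccc(N(Cc2ccc(/C=C/c3c(C)cc(C)cc3C)cc2)C(=O)C(C)C)c1`, gives 149 nM.
Compound 3, `COC(=O)/C=C/c1cccc(N(Cc2ccc(/C=C/c3cccc(F)c3)cc2)C(=O)C(C)C)c1`, gives 71 nM.

Among these three, compound 3 stands with the lowest number: the step of a 2.1-fold lower number from compound 2 to compound 3 (0.32 log units; beyond the scatter) and the step of a 2.7-fold lower number from compound 1 to compound 3 (0.44 log units; beyond the scatter) are both beyond the scatter, so compound 3 needs less compound for the effect than either of the others. The step of a 1.3-fold lower number from compound 1 to compound 2 (0.12 log units; within the scatter) stays within the scatter, so those two cannot be ordered.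

Compound 4, `COC(=O)/C=C/c1cccc(N(Cc2ccc(/C=C/c3ccc(F)cc3)cc2)C(=O)C(C)C)c1`, has not yet been measured. The change from compound 3 is 4-fluorophenyl in place of 3-fluorophenyl on a double-bonded chain carbon bound to a double-bonded chain carbon. The measured steps that bear on this place both arrive at compound 3 from a ring with a different substitution pattern, and both were modest in size. Nothing measured compares a fluorine in one ring position with a fluorine in another, so the shift of the single fluorine is expected to give, at most, a modest step, and most likely none beyond the scatter; the expected step is a 1.2-fold higher number from compound 3 to compound 4 (0.08 log units; within the scatter). For compound 4 the expected value is 85 nM, with the estimated range running from 35 nM to 200 nM.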

Compound 4, half-maximal effective concentration: 120 nM
For compound 4 the middle estimate is 1.4-fold (0.15 log units) below the measured one; measured number inside the range.
By their numbers in this assay, from the lowest: compounds 3, 4, 2 and 1 (each within the scatter of the next, the first and the last beyond it).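

Moving the fluorine from 3-fluorophenyl to 4-fluorophenyl gives a 1.7-fold higher number from compound 3 to compound 4 (0.23 log units; within the scatter) in this assay and is the first direct comparison of one fluorine at two ring positions, and at this size the two compounds cannot be told apart. Compound 4 also cannot be separated from the compounds carrying the larger rings, with a 1.2-fold lower number from compound 2 to compound 4 (0.09 log units; within the scatter) and a 1.6-fold lower number from compound 1 to compound 4 (0.21 log units; within the scatter) as its steps, so it cannot be ordered against any of the other three, even though compound 3 stands clear of compound 1 and compound 2. Nothing measured independently of these numbers bears on how the ring change acts at this place.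

The compounds shown leave open whether any fluorine is needed here, which a plain phenyl ring at the same place would test, and whether 2-fluorophenyl would stand apart from compound 3 and compound 4. They also leave open whether a ring carrying a different single group, such as 3-chlorophenyl or 3-methoxyphenyl, would give a step beyond the scatter from compound 3.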